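From tert-butoxy to 2,2-difluoroethoxy

This account rests on a few compounds, and the source may have more. Where it says the series, first, only, none or still open, it means among the compounds named here.

Measured so far in an ADME assay on S9 fraction from liver (Homo sapiens) for metabolic stability, with a stated time of 1 h; on this read-out lower numbers stand for a less stable compound and higher numbers for a more stable compound:
- compound 1 `N#Cc1cnc(NCc2cncnc2-c2ccccc2)cc1N[C@H]1CC[C@@H](O)CC1`: 42%
- compound 2 `CC(C)(C)Oc1ncncc1CNc1cc(N[C@H]2CC[C@@H](O)CC2)c(C#N)cn1`: 54%

For the measured compounds named here, of these two numbers, compound 2 holds the higher one, with compound 1 as its only neighbour. Compound 3 `N#Cc1cnc(NCc2cncnc2OCC(F)F)cc1N[C@H]1CC[C@@H](O)CC1` has not been measured yet. It differs from compound 2 in one group: 2,2-difluoroethyl in place of tert-butyl on an oxygen on an aromatic ring. In words, 2,2-difluoroethyl sits in place of tert-butyl on an oxygen on an aromatic ring.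

Going by the values given here, only one measured step can serve as a guide, and it is a modest one of a different kind, tert-butoxy in place of phenyl on an aromatic carbon: a number 12 percentage points higher from compound 1 to compound 2 (beyond the scatter). Among the compounds with values here, no measured compound yet carries 2,2-difluoroethyl, so the direction is poorly constrained. The expected result in this assay is a number 2 percentage points higher from compound 2 to compound 3 (within the scatter), a small change that would probably stay within the scatter. For compound 3 the estimate is 56%, with an expected range from 36% to 76%.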

Compound 3, percent of the compound remaining: 87%
Estimate against measurement, compound 3: 31 percentage points below, and the stated range ends below it.
By their numbers in this assay, from the lowest: compound 1; then compound 2; then compound 3.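

In this assay, the group on this oxygen proves to matter a great deal (a number 33 percentage points higher from compound 2 to compound 3 (beyond the scatter)), even though tert-butyl and 2,2-difluoroethyl have the same count of heavy atoms and neither has a ring. Measured against phenyl on the aromatic carbon, 2,2-difluoroethoxy also gives a large step (a number 45 percentage points higher from compound 1 to compound 3 (beyond the scatter)), whereas tert-butoxy gave only a modest one (a number 12 percentage points higher from compound 1 to compound 2 (beyond the scatter)). Nothing measured here accounts for this gain, so its cause remains unknown.

The compounds shown cannot separate the part played by the fluorine atoms from the part played by replacing tert-butyl with a two-carbon group; a plain ethyl or a 2,2,2-trifluoroethyl group on this oxygen would address that. As far as these compounds go, it also remains open whether a longer fluorinated chain would hold this result.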